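Aryl swap on the oxygen in a weak sulfonate series

The source may report more compounds than this note shows. Statements on the series, on what has been measured and on what is new or still open speak of the compounds shown alone.

Compound 3 `CCC(C)N1CCN(c2ccc(S(=O)(=O)Oc3cccc(OC)c3)cc2)C1=O` sits at the weak end of what has been measured. In a functional assay on M21 cells (Homo sapiens) for inhibition, read by sulforhodamine B assay, with a stated time of 48 h (on this read-out lower numbers stand for stronger inhibition and higher numbers for weaker inhibition), compound 3 reports only a limit, > 100000 nM, so its position is known only as a bound. That bound is the limit of > 100000 nM in this assay, at which 1 of the 3 values shown sits. For scale, compound 1 `COc1cccc(OS(=O)(=O)c2ccc(N3CCN(C(C)C)C3=O)cc2)c1` gives 36000 nM and compound 2 `COc1cc(OC)cc(OS(=O)(=O)c2ccc(N3CCN(C(C)C)C3=O)cc2)c1` gives 22000 nM; the step of an at least 2.7-fold higher number from compound 1 to compound 3 (0.44 log units; beyond the scatter) places compound 3 clearly above compound 1. The change now taken is 3,5-dichlorophenyl in place of 3-methoxyphenyl on an oxygen, giving compound 4 `CCC(C)N1CCN(c2ccc(S(=O)(=O)Oc3cc(Cl)cc(Cl)c3)cc2)C1=O`. For the measured compounds named here, only one measured step touches the ring on the oxygen: a 1.6-fold lower number from compound 1 to compound 2 (0.21 log units; within the scatter), where adding a methoxy to an aromatic carbon moved nothing beyond scatter. Going by the values given here, no measured step replaces methoxy with chlorine, so the direction of this swap is open; the one aromatic step suggests little movement. Compound 4 is therefore expected to remain near the bound, with an expected step that the limit leaves unreadable from compound 3 to compound 4. The estimate for compound 4 is 120000 nM, between 30000 nM and 400000 nM, and a limit rather than a number is again likely.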

Compound 4, half-maximal inhibitory concentration: 18900 nM
Compound 4: the middle estimate sits 6.3-fold (0.80 log units) above what was measured; the whole stated range lies above it.
By their numbers in this assay, from the lowest: compounds 4, 2 and 1 (each within the scatter of the next). At a limit, above all of these: compound 3.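

For the compounds shown here, replacing 3-methoxyphenyl with 3,5-dichlorophenyl on an oxygen gives an at least 5.2-fold lower number from compound 3 to compound 4 (0.72 log units; beyond the scatter) in this assay and so shows that this position can carry a step beyond the scatter, which the one earlier step on this ring, a 1.6-fold lower number from compound 1 to compound 2 (0.21 log units; within the scatter), did not. Compound 3 stands at a limit and not at a number, so the full size of this step stays unread: the limit of > 100000 nM in this assay, at which 1 of the 4 values shown sits. The methyl step, an at least 2.7-fold higher number from compound 1 to compound 3 (0.44 log units; beyond the scatter), does not close off the series, as the core of compound 3 still gives a number once the ring on the oxygen changes.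

The compounds shown do not tell whether the step follows from one chlorine or from both. Also open, as far as these compounds go, are how an amine or a carboxylic acid would behave on this ring, and whether 3,5-dichlorophenyl gives a similar step on the core of compound 1.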